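The source may hold more compounds than are shown below. What is called first, only, known or untested is meant among the compounds shown, and "the series" means these compounds.

Measured in an assay on HEK293 cells for inhibition of Ataxin-2 (Mus musculus), read by fluorescence and Amplex Red; a lower number here means a stronger inhibitor, a higher number a weaker inhibitor:

compound 1 `O=C(O)c1ccc(COc2ccc(CN3C(=O)CC[C@H]3C(=O)NCc3ccccc3)cc2)cc1`: a limit, > 5000 nM.
compound 2 `O=C(NCc1ccccc1)[C@@H]1CCC(=O)N1Cc1ccc(OCc2ccc(-c3nn[nH]n3)cc2)cc1`: a limit, > 5000 nM.
compound 3 `O=C(O)c1ccc(COc2ccc(CN3CCC[C@H]3C(=O)NCc3ccccc3)cc2)cc1`: a limit, > 5000 nM.

None of the three measured compounds gives a number in this assay; all three sit at the limit of > 5000 nM in this assay, at which 3 of the 3 values shown sit. The step that the two limits leave unreadable from compound 1 to compound 2 therefore cannot be read, and its structural content is 2H-tetrazol-5-yl in place of carboxy on an aromatic carbon. Compound 3 shares the benzylamide and the aryl ether arm with compound 1, but the difference between the two cores is not broken down here. Compound 4 `O=C(NCc1ccccc1)[C@@H]1CCCN1Cc1ccc(OCc2ccc(-c3nn[nH]n3)cc2)cc1` is the partner of compound 3 in the same sense, differing by 2H-tetrazol-5-yl in place of carboxy on an aromatic carbon; the place line is identical word for word to that of the change from compound 1 to compound 2, so it is the same change on a second core.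

What is expected for compound 4 rests on two facts. Compound 3 gives only the limit > 5000 nM in this assay. Among the compounds with values here, the one measured instance of this change, a step that the two limits leave unreadable from compound 1 to compound 2, left both partners at the limit and so offers no sign of a gain. The step that the limit leaves unreadable from compound 3 to compound 4 is accordingly expected to be small or unreadable. For compound 4 the estimated value in this assay is 10000 nM, with an expected range from 4000 nM to 30000 nM, and most likely the assay will again report only a limit.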

Compound 4, half-maximal inhibitory concentration: > 5000 nM
Compound 4 ended at the assay's limit; the forecaster's own chance of this, stated with the estimate: 85%; the middle value does not contradict the limit.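

In this assay compound 4 gives > 5000 nM, a limit and not a number. Compound 3 also stands at a limit, so no step can be read between compound 3 and compound 4: the limit of > 5000 nM in this assay, at which 4 of the 4 values shown sit.

Still open, as far as these compounds go, is whether compound 1, compound 2, compound 3 and compound 4 differ at all in this assay, and how carboxy and 2H-tetrazol-5-yl would rank on either core.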